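Shifting the amine end of a flavone chain

A few compounds are considered here, and "the series" means these few. Any claim that something is new, unique, unknown or untested is made for them only; others in the source may bear on it.

Compound 2 `CN(CCCCCCOc1ccc2oc(-c3ccccc3)cc(=O)c2c1)Cc1ccccc1` holds the lower of the two numbers in an assay on isolated protein (Cavia porcellus) with Sigma non-opioid intracellular receptor 1 (Homo sapiens) as the target, read by radioligand binding (a lower number here means a stronger inhibitor, a higher number a weaker inhibitor), giving 52 nM, while compound 1 `CN(C)CCCCCCOc1ccc2oc(-c3ccccc3)cc(=O)c2c1` gives 432 nM. Among the compounds with values here, the only step between them is an 8.3-fold lower number from compound 1 to compound 2 (0.92 log units; beyond the scatter). On these data alone, compound 3 `O=c1cc(-c2ccccc2)oc2ccc(OCCCCCCN3CCNCC3c3ncccn3)cc12` is untested and differs from compound 2 by 2-(pyrimidin-2-yl)piperazin-1-yl in place of benzyl(methyl)amino on a saturated chain carbon, six bonds along the chain from an oxygen on an aromatic ring. The step from compound 1 to compound 2 bears on this change only in reverse, because the benzyl that drove an 8.3-fold lower number from compound 1 to compound 2 (0.92 log units; beyond the scatter) is removed here, and nothing measured shows what the entering group contributes. Compound 3 is therefore expected to lose part of that gain, with a step of a 3.8-fold higher number from compound 2 to compound 3 (0.59 log units; beyond the scatter) toward a weaker inhibitor. Compound 3 is estimated at 200 nM in this assay, within a range from 50 nM to 800 nM.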

Compound 3, half-maximal inhibitory concentration: 1630 nM
Beside the measured number, compound 3's estimate is 8.2-fold (0.91 log units) below it; the measured number lies above the stated range.
By their numbers in this assay, from the lowest: compound 2; then compound 1; then compound 3.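

In this assay, 2-(pyrimidin-2-yl)piperazin-1-yl in place of benzyl(methyl)amino gives a 31-fold higher number from compound 2 to compound 3 (1.50 log units; beyond the scatter) at this chain end, so the entering group does not keep what the benzyl-bearing amine had gained. The same group in place of dimethylamino gives a 3.8-fold higher number from compound 1 to compound 3 (0.58 log units; beyond the scatter) as well, which places compound 3 behind both open-chain amines. This position can therefore cost binding as well as gain it, depending on the amine placed there. Nothing at hand explains the size of this loss.

The compounds shown leave open whether the loss follows the piperazine ring or the pyrimidin-2-yl group on it, a question that plain piperazin-1-yl on the same chain could address. They also leave open whether a benzyl group on the piperazine nitrogen would restore the lower number seen for compound 2.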